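The source may hold more compounds than are shown below. What is called first, only, known or untested is meant among the compounds shown, and "the series" means these compounds.

Compound 1 `CCCc1nc(-c2ccccc2)c(CNCCCN2CCN(c3ccc(OC)cc3)CC2)o1` — in an assay on HEK293 cells for inhibition of Voltage-dependent T-type calcium channel subunit alpha-1G (Homo sapiens), read by fluorescence, tested at 10 uM (on this read-out higher numbers stand for more inhibition at the one concentration tested (going by the name of the read-out) and lower numbers for less inhibition), compound 1 gives 42.1%.
Compound 2 `CCCc1nc(-c2ccccc2)c(CNCCCN2CCN(c3cccc(Cl)c3)CC2)o1` — in this assay compound 2 gives 65.9%.
Compound 3 `CCCc1nc(-c2ccccc2)c(CNCCCN2CCN(c3ccc(C(F)(F)F)cc3)CC2)o1` — in this assay compound 3 gives 51.6%.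

Compound 3 stands second highest of the three. Its nearest neighbour is compound 1, a gap within the scatter, so nothing separates the two; compound 2 lies furthest away, and the step of a number 14.3 percentage points lower from compound 2 to compound 3 (beyond the scatter) is beyond the scatter. Compound 4 `CCCc1nc(-c2ccccc2)c(CNCCCN2CCN(c3ccccc3OC)CC2)o1` differs from compound 3 in one place: 2-methoxyphenyl in place of 4-(trifluoromethyl)phenyl on an amine nitrogen in a ring. Going by the values given here, two measured steps bear on this change. The step of a number 9.5 percentage points higher from compound 1 to compound 3 (within the scatter) swaps a methoxy for a trifluoromethyl on the same aryl group and stays within the scatter, while a number 14.3 percentage points lower from compound 2 to compound 3 (beyond the scatter) shows that a change of the aryl group can move the number modestly. Compound 4 carries a methoxyphenyl, as compound 1 does, though as 2-methoxyphenyl rather than 4-methoxyphenyl, and compound 1 gives 42.1%. The step of a number 6.6 percentage points lower from compound 3 to compound 4 (within the scatter) is therefore expected to be small, if anything downward, and within the scatter. For compound 4 the estimate in this assay is 45%, with a range from 25% to 65%.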

Compound 4, a percentage reported as inhibition, at one concentration (the size of the read-out at that concentration, not a potency): 41%
For compound 4 the middle estimate is 4 percentage points above the measured one, within the range that was stated.
By their numbers in this assay, from the lowest: compounds 4, 1 and 3 (each within the scatter of the next, the first and the last beyond it); then compound 2.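

In this assay, the step of a number 1.1 percentage points lower from compound 1 to compound 4 (within the scatter) stays within the scatter, so 2-methoxyphenyl and 4-methoxyphenyl on the amine nitrogen in a ring cannot be told apart. Compound 3 could not be separated from compound 1, yet the step of a number 10.6 percentage points lower from compound 3 to compound 4 (beyond the scatter) lies beyond the scatter, so 4-(trifluoromethyl)phenyl now stands apart from one of the two methoxyphenyl groups but not from the other. Going by these compounds alone, the step of a number 24.9 percentage points lower from compound 2 to compound 4 (beyond the scatter) is also beyond the scatter, and 3-chlorophenyl remains the only group here whose steps to all the others lie beyond it.

Nothing at hand accounts for these differences. Left open is whether the number of compound 2 goes with chlorine itself or with where it sits on the phenyl, and how a plain phenyl or a pyridine ring would read on that amine nitrogen.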